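A smaller aromatic group on compound 3

The source may hold more compounds than are shown below. What is called first, only, known or untested is meant among the compounds shown, and "the series" means these compounds.

Of the compounds shown here, three have numbers so far in a functional assay on MDA-MB-231 cells (Homo sapiens) for antiproliferative activity, read by MTT assay, with a stated time of 48 h; a higher number here means a weaker inhibitor, a lower number a stronger inhibitor. Compound 1 `C=CS(=O)(=O)N1CCN(c2ncnc3ccc(-c4ccccc4)cc23)CC1` gives 47900 nM, compound 2 `C=CS(=O)(=O)N1CCN(c2ncnc3sc(-c4ccc(N5CCN(C)CC5)cc4)cc23)CC1` gives 7550 nM, and compound 3 `C=CS(=O)(=O)N1CCN(c2ncnc3sc(-c4cccc5ncccc45)cc23)CC1` gives 21000 nM. Compound 3 therefore sits in the middle, with a lower number than compound 1 and a higher number than compound 2, and both gaps lie beyond the usual scatter of repeated measurements.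

Compound 4 `C=CS(=O)(=O)N1CCN(c2ncnc3sc(-c4c(C)noc4C)cc23)CC1` keeps the core of compound 3 and changes one group, on an aromatic carbon of a five-membered aromatic ring with 1 sulfur, next to the ring sulfur: 3,5-dimethyl-1,2-oxazol-4-yl in place of quinolin-5-yl on an aromatic carbon. Here 3,5-dimethyl-1,2-oxazol-4-yl takes the place of quinolin-5-yl.

Among the measured compounds shown here, no two measured compounds differ in one place only, so the only guide is the narrow span from compound 2 at 7550 nM to compound 1 at 47900 nM. A small move towards weaker inhibition is expected, a 1.4-fold higher number from compound 3 to compound 4 (0.15 log units; within the scatter), which would not stand beyond the scatter. For compound 4 the estimated value is 30000 nM, with an expected range from 12000 nM to 75000 nM.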

Compound 4, half-maximal inhibitory concentration: 28200 nM
Beside the measured number, compound 4's estimate is 1.1-fold (0.03 log units) above it; measured number inside the range.
By their numbers in this assay, from the lowest: compound 2; then compounds 3, 4 and 1 (each within the scatter of the next, the first and the last beyond it).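

In this assay this swap gives a 1.3-fold higher number from compound 3 to compound 4 (0.13 log units; within the scatter) and so the two compounds cannot be told apart. On this aromatic carbon next to the ring sulfur, quinolin-5-yl, with 10 heavy atoms in two six-membered aromatic rings, and 3,5-dimethyl-1,2-oxazol-4-yl, with 7 heavy atoms in one five-membered aromatic ring, give numbers within the usual scatter despite their different size and ring type. Nothing measured here explains why these two groups give such similar numbers.

From the compounds shown here alone, whether a carboxylic acid or a simple amine such as aminomethyl at this position would move the number beyond the scatter remains open. So does the part played by the two methyl groups on the 1,2-oxazole ring, which a hydrogen or an ethyl group in their place could test.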